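Series notes: stereocentre inversion from compound 3 to compound 4

A few compounds are considered here, and "the series" means these few. Any claim that something is new, unique, unknown or untested is made for them only; others in the source may bear on it.

Measured so far in a functional assay on isolated protein for inhibition of Glucose-dependent insulinotropic receptor (Rattus norvegicus), read by HTRF and cAMP accumulation; on this read-out lower numbers stand for smaller maximal responses and higher numbers for larger maximal responses:
- compound 1, `Cc1nc(S(C)(=O)=O)ccc1Oc1ncnc(OC2CCN(C(=O)OC(C)(C)CF)CC2)c1F`, gives 95%
- compound 2, `Cc1nc(S(C)(=O)=O)ccc1Oc1ncnc(OC2CCN(C(=O)OC(C)F)CC2)c1F`, gives 68%
- compound 3, `Cc1nc(S(C)(=O)=O)ccc1Oc1ncnc(OC2CCN(C(=O)O[C@H](C)C(F)(F)F)CC2)c1F`, gives 85%

Compound 3 stands second highest of the three; its nearest neighbour is compound 1, with a number 10 percentage points lower from compound 1 to compound 3 (within the scatter), and its furthest is compound 2, with a number 17 percentage points higher from compound 2 to compound 3 (beyond the scatter). Compound 4, `Cc1nc(S(C)(=O)=O)ccc1Oc1ncnc(OC2CCN(C(=O)O[C@@H](C)C(F)(F)F)CC2)c1F`, has not been measured. Its difference from compound 3: the two compounds have the same atoms and bonds and differ only in configuration as drawn: 1 of 1 stereo elements differ; a stereocentre at a saturated chain carbon is drawn R in compound 3 and S in compound 4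

Within the data shown here, no measured pair differs in configuration alone; the two steps that end at compound 3 alter the group on that oxygen, not its configuration, so they set only the range of this series. A step of either sign, or none beyond the scatter, is plausible. Compound 4 is estimated at 75%, range 50% to 95%, which means an expected step of a number 10 percentage points lower from compound 3 to compound 4 (within the scatter).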

Compound 4, largest response reached (reported as efficacy), in percent of the reference or control that the assay uses: 80%
Beside the measured number, compound 4's estimate is 5 percentage points below it, within the range that was stated.
By their numbers in this assay, from the lowest: compound 2; then compounds 4, 3 and 1 (each within the scatter of the next, the first and the last beyond it).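

In this assay, among these compounds, inverting the stereocentre of the 1-(trifluoromethyl)ethyl group gives a number 5 percentage points lower from compound 3 to compound 4 (within the scatter), the first reading of configuration alone at this position, and the comparison isolates that single change: the fact that compounds 3 and 4 differ only in the configuration as drawn. The S form keeps its separation from the 1-fluoroethyl group, with a number 12 percentage points higher from compound 2 to compound 4 (beyond the scatter). Among the compounds shown here, it also gives a number 15 percentage points lower from compound 1 to compound 4 (beyond the scatter), though that gap cannot be set against the one for compound 3 as a real effect of configuration, since compound 3 and compound 4 lie within the scatter of each other.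

From the compounds shown here alone, whether configuration matters for the 1-fluoroethyl group, drawn without one in compound 2, stays open. So does the response to a longer chain on that oxygen.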